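This account rests on a few compounds, and the source may have more. Where it says the series, first, only, none or still open, it means among the compounds named here.

Compound 1 `O=C1O/C(=C\Cn2cc(-c3ccc(Br)cc3)nn2)C(OCc2ccccc2)=C1OCc1ccccc1` stands at the ceiling of a functional assay on HCT-116 cells (Homo sapiens) for antiproliferative activity, read by MTT assay, with a stated time of 72 h; a lower number here means a stronger inhibitor, a higher number a weaker inhibitor: its value of > 100000 nM is a limit of that assay, not a number. For the measured compounds named here, compound 2 `O=C1O[C@H]([C@@H](O)Cn2cc(-c3cc(C(F)(F)F)cc(C(F)(F)F)c3)nn2)C(OCc2ccccc2)=C1OCc1ccccc1` gives 57200 nM in this assay, and compound 3 `CCCCc1cn(C[C@H](O)[C@H]2OC(=O)C(OCc3ccccc3)=C2OCc2ccccc2)nn1` gives 10400 nM; no step is drawn between these three, since each differs from the others in more than one place. Compound 4 `COc1ccc(-c2cn(C/C=C3\OC(=O)C(OCc4ccccc4)=C3OCc3ccccc3)nn2)cc1` has yet to be measured; it differs from compound 1 by methoxy in place of bromo on an aromatic carbon. Going by the values given here, because compound 1 is known only through (the limit of > 100000 nM in this assay, at which 1 of the 3 values shown sits), no measured pair gives a numeric size for this kind of change. The step of a number no higher from compound 1 to compound 4 (the limit leaves the size open) is expected to lie within the scatter. Compound 4 is therefore estimated at 100000 nM, in the range 30000 nM to 300000 nM, most likely reported again as a limit.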

Compound 4, half-maximal inhibitory concentration: > 100000 nM
Compound 4 ended at the assay's limit (the forecaster's own chance of this, stated with the estimate: 70%); the middle value sits exactly at the limit.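

No new step can be read from compound 1 to compound 4, because both values are limits: the limit of > 100000 nM in this assay, at which 2 of the 4 values shown sit.

The compounds shown leave open what size, if any, the change from 4-bromophenyl to 4-methoxyphenyl has on activity.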